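Swapping the ring substituent on a pyridinyl-piperazine oxime series

This account rests on a few compounds, and the source may have more. Where it says the series, first, only, none or still open, it means among the compounds named here.

Measured compounds in a functional assay on HEK293 cells with D(4) dopamine receptor (Homo sapiens) as the target, read by FLIPR; on this read-out lower numbers stand for an effect already at smaller amounts and higher numbers for an effect only at larger amounts of compound:
- compound 1, `O/N=C(\CCN1CCN(c2ccccn2)CC1)c1ccccc1`: 4.4 nM
- compound 2, `O/N=C(\CCN1CCN(c2ccccn2)CC1)c1cccc(Cl)c1`: 11.9 nM
- compound 3, `N#Cc1cccc(/C(CCN2CCN(c3ccccn3)CC2)=N/O)c1`: 13.1 nM

All three share the same core and differ only in the aromatic ring attached to the carbon that carries the double bond to nitrogen. Compound 3 has the highest number of the three; its value and that of compound 2 are within the scatter of each other, while compound 1 stands clearly lower, since the step of a 3.0-fold higher number from compound 1 to compound 3 (0.47 log units; beyond the scatter) lies beyond the scatter.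

Compound 4, `O/N=C(\CCN1CCN(c2ccccn2)CC1)c1ccc(F)cc1`, has not yet been measured. It differs from compound 3 in this way: 4-fluorophenyl in place of 3-cyanophenyl on a carbon with a double bond to nitrogen. For the measured compounds named here, no measured step covers exactly this change. What bears on it is that adding a substituent to the ring of compound 1 raised the number in both known cases, a 2.7-fold higher number from compound 1 to compound 2 (0.43 log units; beyond the scatter) and a 3.0-fold higher number from compound 1 to compound 3 (0.47 log units; beyond the scatter), and that changing one substituent for another, a 1.1-fold higher number from compound 2 to compound 3 (0.04 log units; within the scatter), did not move it. Compound 4 carries a different substituent in a different place, so its number is expected to fall between that of compound 1 and compound 3. The step of a 1.9-fold lower number from compound 3 to compound 4 (0.27 log units; within the scatter) is therefore expected to be a modest lowering, close to the edge of the scatter. Compound 4 is estimated at 7 nM, with a range from 2.5 nM to 18 nM.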

Compound 4, half-maximal effective concentration: 31 nM
The estimate for compound 4 lay 4.4-fold (0.65 log units) below the measured number; the whole stated range lies below it.
By their numbers in this assay, from the lowest: compound 1; then compounds 2 and 3 (each within the scatter of the next); then compound 4.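

In this assay, adding a fluoro group to the ring of compound 1 gives the largest rise in the series (a 7.0-fold higher number from compound 1 to compound 4 (0.85 log units; beyond the scatter)), larger than the rises for chloro (a 2.7-fold higher number from compound 1 to compound 2 (0.43 log units; beyond the scatter)) and cyano (a 3.0-fold higher number from compound 1 to compound 3 (0.47 log units; beyond the scatter)). The swap from 3-chlorophenyl to 3-cyanophenyl had left the number within the scatter, but moving to 4-fluorophenyl on this same carbon with a double bond to nitrogen shifts it beyond the scatter (a 2.6-fold higher number from compound 2 to compound 4 (0.42 log units; beyond the scatter); a 2.4-fold higher number from compound 3 to compound 4 (0.37 log units; beyond the scatter)), so a substituted ring here is not interchangeable with every other substituted ring. Nothing available offers an explanation for this rise.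

Fluoro appears only in 4-fluorophenyl, chloro only in 3-chlorophenyl and cyano only in 3-cyanophenyl, so these compounds cannot separate the effect of the group from the effect of its place on the ring. They also leave open how a methoxy group or an amine on this ring would read, and whether any such group could match the unsubstituted phenyl ring of compound 1.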